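The source may hold more compounds than are shown below. What is called first, only, known or untested is meant among the compounds shown, and "the series" means these compounds.

Compound 1 `Cc1ccccc1-n1nc(C)c2c1NC(=O)[C@H](C)S[C@@H]2c1ccc(/C=C/c2ccccc2)cc1` sits in a series whose core also carries compound 2 `Cc1nn(-c2ccccc2C(C)C)c2c1[C@@H](c1ccc(Oc3ccccc3)cc1)S[C@@H](C)C(=O)N2` and compound 3 `Cc1nn(-c2ccccc2F)c2c1C(c1ccc(Oc3ccccc3)cc1)SC(C)C(=O)N2`, each bearing a phenoxy-substituted aryl on the shared core. In an assay on isolated protein for agonist activity at Bile acid receptor (Homo sapiens), read by AlphaScreen, with a stated time of 30 min (a lower number here means that less compound is needed, a higher number that more compound is needed for the effect), compound 2 gives 1900 nM. In this assay compound 3 gives 3900 nM, and those two values lie within the usual scatter of each other. In this assay compound 1 is reported as "not active" (no number reported), so no number places it beside them. Compound 4 `COc1ccccc1-c1ccc([C@H]2S[C@@H](C)C(=O)Nc3c2c(C)nn3-c2ccccc2C)cc1` differs from compound 1 by 2-methoxyphenyl in place of 2-phenylethenyl on an aromatic carbon. Among the measured compounds shown here, with no measured step for that change, only a weak signal from the phenoxy compounds is expected, in the direction of a measurable value rather than none. The value of compound 4 in this assay is expected near 3000 nM, within 800 nM to 15000 nM.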

Compound 4, half-maximal effective concentration: 1100 nM
For compound 4 the middle estimate is 2.7-fold (0.44 log units) above the measured one; the range from low to high includes it.
By their numbers in this assay, from the lowest: compounds 4 and 2 (each within the scatter of the next); then compound 3.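

In this assay compound 1 gives "not active" (no number reported) and so offers no readable step to compound 4. The compounds shown leave open how 2-methoxyphenyl and 2-phenylethenyl compare numerically on the shared core. No evidence shown bears on this result.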